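This account rests on a few compounds, and the source may have more. Where it says the series, first, only, none or still open, it means among the compounds named here.

Compound 1 `C=C1C(=O)O[C@H]2CC3=C[C@H](C/C(C)=C/[C@@H](OC(=O)c4ccc(-c5ccccc5)cc4)[C@H]12)OC3=O` gives 3500 nM in a functional assay on NCI-H460 cells (Homo sapiens) for cytotoxicity, read by MTT assay, with a stated time of 48 h; on this read-out lower numbers stand for stronger inhibition and higher numbers for weaker inhibition.
Compound 2 `C=C1C(=O)O[C@H]2CC3=C[C@H](C/C(C)=C/[C@@H](OC(=O)/C=C/c4cccc(OC)c4)[C@H]12)OC3=O` gives only a limit of the assay in this assay, > 10000 nM.
Compound 3 `C=C1C(=O)O[C@H]2CC3=C[C@H](C/C(C)=C/[C@@H](OC(=O)CCCCC)[C@H]12)OC3=O` gives 5900 nM in this assay.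

Among the two numbers in this assay, compound 3 stands highest, with compound 1 close enough to lie within the scatter. Compound 4 `C=C1C(=O)O[C@H]2CC3=C[C@H](C/C(C)=C/[C@@H](OC(=O)/C=C/c4ccncc4)[C@H]12)OC3=O` has not yet been measured; it differs from compound 3 by 2-(pyridin-4-yl)ethenyl in place of pentyl on a carbonyl carbon. Within the data shown here, one measured step bears on this change: an at least 1.6-fold lower number from compound 2 to compound 3 (0.22 log units; that floor lies within the scatter), where the starting point was only a limit (the limit of > 10000 nM in this assay, at which 1 of the 3 values shown sits). Since compound 4 again carries an ethenyl-linked aromatic ring on the carbonyl carbon, like compound 2, the number is expected to rise back toward that limit. The expected step for compound 4 is a 1.5-fold higher number from compound 3 to compound 4 (0.18 log units; within the scatter). The estimate for compound 4 is 9000 nM, with a range from 4000 nM to 20000 nM.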

Compound 4, half-maximal inhibitory concentration: 2100 nM
Compound 4: middle estimate off by 4.3-fold (0.63 log units), on the high side; the measured number lies below the stated range.
By their numbers in this assay, from the lowest: compounds 4, 1 and 3 (each within the scatter of the next, the first and the last beyond it). At a limit, above all of these: compound 2.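

On this carbonyl carbon, an ethenyl-linked aromatic ring need not go with a weak number in this assay, since 2-(pyridin-4-yl)ethenyl in place of pentyl gives a 2.8-fold lower number from compound 3 to compound 4 (0.45 log units; beyond the scatter) on the shared core. With the ethenyl link kept, the ring itself also matters, as pyridin-4-yl in place of 3-methoxyphenyl gives an at least 4.7-fold lower number from compound 2 to compound 4 (0.67 log units; beyond the scatter) in this pair. That step is only a floor, its starting point being a limit: the limit of > 10000 nM in this assay, at which 1 of the 4 values shown sits.

On these data alone, whether the gain belongs to the pyridine nitrogen or to the ethenyl link stays open. A plain phenyl on the same link, or a saturated 2-(pyridin-4-yl)ethyl chain, would separate the two.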